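Swapping the phenyl for an ethynyl link at the limit

The source may hold more compounds than are shown below. What is called first, only, known or untested is meant among the compounds shown, and "the series" means these compounds.

Values in a functional assay on MX1 cells (Homo sapiens) for inhibition, read by MTT assay, with a stated time of 120 h (on this read-out higher numbers stand for weaker inhibition and lower numbers for stronger inhibition), so far:
Compound 1 `CC(NC(=O)c1cccc(-c2ccc(NC(=O)Nc3ccc(Cl)c(C(F)(F)F)c3)cc2)c1)c1ccccc1` gives 5240 nM
Compound 2 `CC(NC(=O)C#Cc1ccc(NC(=O)Nc2ccc(Cl)c(C(F)(F)F)c2)cc1)c1ccccc1` gives 12800 nM
Compound 3 `CNC(=O)c1cccc(-c2ccc(NC(=O)Nc3ccc(Cl)c(C(F)(F)F)c3)cc2)c1` gives > 50000 nM as a limit

Compound 3 has no number of its own, only a limit (the limit of > 50000 nM in this assay, at which 1 of the 3 values shown sits). Compound 4 `CNC(=O)C#Cc1ccc(NC(=O)Nc2ccc(Cl)c(C(F)(F)F)c2)cc1` carries 2-(methylcarbamoyl)ethynyl in place of 3-(methylcarbamoyl)phenyl on an aromatic carbon.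

Among the compounds with values here, one measured step bears on this change. It is an at least 9.5-fold higher number from compound 1 to compound 3 (0.97 log units; beyond the scatter) and it shows what happened on the phenyl-linked side when methyl replaced 1-phenylethyl on an amide-type nitrogen. Compound 4 has the same methyl amide as compound 3 and the same ethynyl link as compound 2. With 1-phenylethyl in place, compound 1 gives 5240 nM and compound 2 gives 12800 nM in this assay, so the ethynyl link does not bring a lower number there. If compound 2 took a step of the size of an at least 9.5-fold higher number from compound 1 to compound 3 (0.97 log units; beyond the scatter), compound 4 would be expected to land past the limit.

The expected size is a step that the limit leaves unreadable from compound 3 to compound 4 and no real gain is expected in this comparison. Compound 4 is estimated at 60000 nM in a likely range of 25000 nM to 150000 nM and will probably be reported only as a limit.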

Compound 4, half-maximal inhibitory concentration: 26400 nM
Estimate against measurement, compound 4: 2.3-fold (0.36 log units) above, and the stated range covers the measured number.
By their numbers in this assay, from the lowest: compound 1; then compound 2; then compound 4. At a limit, above all of these: compound 3.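

Compound 3 has only a limit in this assay, > 50000 nM. Against that limit, putting 2-(methylcarbamoyl)ethynyl in place of 3-(methylcarbamoyl)phenyl gives an at least 1.8-fold lower number from compound 3 to compound 4 (0.27 log units; that floor lies within the scatter), so with the methyl amide the ethynyl-linked compound has a measurable number, while the true size of the change stays unknown and its floor lies within the scatter. Going from 1-phenylethyl to methyl on the amide nitrogen also raises the number on the ethynyl-linked core, with a 2.1-fold higher number from compound 2 to compound 4 (0.31 log units; beyond the scatter), and the change costs far more on the phenyl-linked core than on the ethynyl-linked one: the same change on two cores in this assay, an at least 9.5-fold higher number (0.97 log units; beyond the scatter) from compound 1 to compound 3 and a 2.1-fold higher number (0.31 log units; beyond the scatter) from compound 2 to compound 4, at least 4.6-fold (0.66 log units) apart, beyond the scatter of two such steps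

The compounds shown compare only 1-phenylethyl and methyl on the amide nitrogen, so it remains open whether a benzyl or an ethyl group there would show how much of the lower numbers comes from the phenyl ring and how much from the branched carbon. From the compounds shown here alone, it is also open how the number would move if a carboxylic acid or an amine took the place of the amide at the end of the ethynyl link.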